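A few compounds are considered here, and "the series" means these few. Any claim that something is new, unique, unknown or untested is made for them only; others in the source may bear on it.

In a functional assay on PC-3 cells (Homo sapiens) for inhibition, read by sulforhodamine B assay (a lower number here means a stronger inhibitor of growth, a higher number a weaker inhibitor of growth), compound 1 `c1ccc(-c2ccc(-c3ccc(-c4nc5ccccc5[nH]4)cc3)cc2)cc1` gives 41200 nM, while compound 2 `Oc1cccc2[nH]c(-c3ccc(-c4ccc(-c5ccccc5)cc4)cc3)nc12` gives 1240 nM, the lower of the two numbers. For the measured compounds named here, the only measured step, a 33-fold lower number from compound 1 to compound 2 (1.52 log units; beyond the scatter), came with hydroxy in place of hydrogen on an aromatic carbon. Compound 3 `Oc1cccc2[nH]c(-c3ccc(-c4ccc(-c5ccc(C(F)(F)F)cc5)cc4)cc3)nc12` keeps that hydroxy and differs from compound 2 by trifluoromethyl in place of hydrogen on an aromatic carbon. The measured step lies at another place in the structure and involves another group, so it sets no size for this change. Going by the values given here, no measured pair shows what trifluoromethyl does, and so no step beyond the scatter is expected in this assay, though the uncertainty is wide. The expected change is a 1.2-fold lower number from compound 2 to compound 3 (0.09 log units; within the scatter). Compound 3 is estimated at 1000 nM, with an expected range of 300 nM to 4000 nM.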

Compound 3, concentration for 50% growth inhibition: 2260 nM
For compound 3 the middle estimate is 2.3-fold (0.35 log units) below the measured one, and the stated range covers the measured number.
By their numbers in this assay, from the lowest: compounds 2 and 3 (each within the scatter of the next); then compound 1.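

In this assay, for the compounds shown here, the change from phenyl to 4-(trifluoromethyl)phenyl gives a 1.8-fold higher number from compound 2 to compound 3 (0.26 log units; within the scatter), the first reading at this position, and it stands in contrast to the larger step seen on adding the hydroxy. A trifluoromethyl group of four heavy atoms, placed para to a large group on this six-membered aromatic ring, therefore leaves the number of the hydroxy compound within the usual scatter in this assay. Nothing available explains why this position responds so little to the change.

As far as these compounds go, whether an amine, a carboxylic acid or a methoxy group at this same carbon would leave the number equally unmoved remains open. A single substituent also cannot show whether the position is insensitive in general, or whether trifluoromethyl would behave the same way elsewhere on this ring.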